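The source may report more compounds than this note shows. Statements on the series, on what has been measured and on what is new or still open speak of the compounds shown alone.

In a functional assay on T47D cells (Homo sapiens) for cytotoxicity, read by CCK-8 assay (on this read-out lower numbers stand for stronger inhibition and higher numbers for weaker inhibition), compound 1 `Oc1cccc(-c2cc(-c3cccs3)cc(-c3ccccc3O)n2)c1` gives > 50000 nM, which is a limit of the assay and not a number. Compound 2 `Oc1ccc(-c2cc(-c3cccs3)cc(-c3ccccc3O)n2)cc1` gives > 50000 nM, also a limit. Compound 1 therefore sits at the limit of > 50000 nM in this assay, at which 2 of the 3 values shown sit. Compound 3 `Oc1cccc(-c2cc(-c3cccs3)cc(-c3cccc(O)c3)n2)c1` gives a true number of 770 nM.

Compound 4 `Oc1cccc(-c2cc(-c3ccco3)cc(-c3ccccc3O)n2)c1` differs from compound 1 in one place: furan-2-yl in place of thiophen-2-yl on an aromatic carbon. Its 2-hydroxyphenyl and 3-hydroxyphenyl groups stay as they were.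

The measured steps concern only the hydroxyphenyl groups. The large step of an at least 64-fold lower number from compound 1 to compound 3 (1.81 log units; beyond the scatter) replaced the 2-hydroxyphenyl group with 3-hydroxyphenyl, whereas a step that the two limits leave unreadable from compound 1 to compound 2 cannot be sized. Among the compounds with values here, no measured step swaps the five-membered ring, so the evidence is indirect. Compound 4 keeps the 2-hydroxyphenyl group that compound 3 lost in an at least 64-fold lower number from compound 1 to compound 3 (1.81 log units; beyond the scatter), so the large gain is not expected to appear here.

In this assay, the expected change is small and of no firm direction, with an estimated step of an at least 1.2-fold lower number from compound 1 to compound 4 (0.09 log units; that floor lies within the scatter). For compound 4 the estimated value is 40000 nM, with an expected range of 5000 nM to 80000 nM.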

Compound 4, half-maximal inhibitory concentration: 820 nM
For compound 4 the middle estimate is 49-fold (1.69 log units) above the measured one, outside the stated range (below it).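

In this assay, the position opposite the ring nitrogen turns out to matter: furan-2-yl in place of thiophen-2-yl brings an at least 60-fold lower number from compound 1 to compound 4 (1.78 log units; beyond the scatter). Until now, only a change in a hydroxyphenyl group had produced a large step, so compound 4 shows that a second single change, in the five-membered ring, can also lift the core of compound 1 off its limit. The step can be given only as a floor, because the value for compound 1 is a limit and not a number: the limit of > 50000 nM in this assay, at which 2 of the 4 values shown sit.

The compounds shown leave open whether furan-2-yl would bring a similar step on compound 2 or compound 3, where the hydroxyphenyl groups differ. They also leave open how an amine or a carboxylic acid would read at this position.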